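A few compounds are considered here, and "the series" means these few. Any claim that something is new, unique, unknown or untested is made for them only; others in the source may bear on it.

Two compounds of this series have been run so far in a functional assay on C6 cells (Rattus norvegicus) for cytotoxicity, read by MTT assay, with a stated time of 24 h, tested at 50 ug/mL; a lower number here means a stronger effect, a higher number a weaker effect of the compound at the concentration tested. Compound 1 `Cc1ccc(-c2cs/c(=N/NC(=O)CSc3nncn3C)n2-c2ccccc2)cc1` gives 53.8% in this assay. Compound 2 `O=C(CSc1ncccn1)N/N=c1/scc(-c2ccc(Cl)cc2)n1-c1ccccc1` gives 61.8% in this assay, the highest of the two numbers recorded, with compound 1 as its nearest neighbour, lower by a gap that stays within the usual scatter; no order between the two can be drawn from these values. Among the compounds with values here, compound 1 and compound 2 differ in more than one place, so no single-point step between measured compounds is available to read from.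

Compound 3 `Cc1ccc(-c2cs/c(=N/NC(=O)CSc3ncccn3)n2-c2ccccc2)cc1` has not yet been measured. It differs from compound 2 in one place only: methyl in place of chloro on an aromatic carbon. Cut one bond further out, the change reads 4-chlorophenyl to 4-methylphenyl. Within the data shown here, with no measured step at this position to lean on, and with the two measured values lying within scatter of each other, the step from compound 2 to compound 3 in this assay is expected to be small, with no direction that stands out beyond the scatter, estimated as a number 3.8 percentage points lower from compound 2 to compound 3 (within the scatter). Compound 3 is accordingly estimated at 58% in this assay, with an expected range from 45% to 72%.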

Compound 3, a percentage reported as activity, at one concentration (the size of the read-out at that concentration, not a potency): 64.4%
Estimate against measurement, compound 3: 6.4 percentage points below; low and high end bracket the measured number.
By their numbers in this assay, from the lowest: compounds 1, 2 and 3 (each within the scatter of the next, the first and the last beyond it).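

In this assay the series now has its first single-point readings. At the aromatic carbon para to a large group, 4-methylphenyl in place of 4-chlorophenyl gives a number 2.6 percentage points higher from compound 2 to compound 3 (within the scatter) and so shows no readable difference between chloro and methyl in this pair, while the group on the sulfur gives a number 10.6 percentage points higher from compound 1 to compound 3 (beyond the scatter) with pyrimidin-2-yl in place of 4-methyl-4H-1,2,4-triazol-3-yl, a modest weakening of the effect at the concentration tested that rests on this single pair with 4-methylphenyl held constant. No measurement on these compounds offers an explanation for either step.

The compounds shown leave open whether the step on the sulfur carries over when 4-chlorophenyl takes the place of 4-methylphenyl. Going by these compounds, it also remains open how the para position responds to a group of another kind, such as an amine or a carboxylic acid, and whether a group other than these two rings on the sulfur would move the number further in either direction.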